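This account rests on a few compounds, and the source may have more. Where it says the series, first, only, none or still open, it means among the compounds named here.

Measured compounds in a functional assay on MDA-MB-231 cells (Homo sapiens) for antiproliferative activity, read by MTT assay, with a stated time of 24 h; on this read-out lower numbers stand for stronger inhibition and higher numbers for weaker inhibition:
compound 1 `CCSc1nnc(COc2cc(C)c3c(C)cc(=O)oc3c2)o1`: compound 1 gives > 100000 nM, a limit of the assay.
compound 2 `CCCS(=O)(=O)c1nnc(COc2cc(C)c3c(C)cc(=O)oc3c2)o1`: compound 2 gives 7070 nM.
compound 3 `CCCCCCS(=O)(=O)c1nnc(COc2cc(C)c3c(C)cc(=O)oc3c2)o1`: compound 3 gives > 100000 nM, a limit of the assay.

Among the measured compounds shown here, compound 3 therefore stands at the limit, and compound 1 shares that limit (the limit of > 100000 nM in this assay, at which 2 of the 3 values shown sit); compound 2 is the only member of the series with a numerical value. The two readable steps are both large: an at least 14-fold lower number from compound 1 to compound 2 (1.15 log units; beyond the scatter) and, in the opposite direction, an at least 14-fold higher number from compound 2 to compound 3 (1.15 log units; beyond the scatter). The step that the two limits leave unreadable from compound 1 to compound 3 cannot be sized, since both ends sit at the limit.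

Compound 4 `Cc1cc(OCc2nnc(S(=O)(=O)Cc3cccc(F)c3)o2)cc2oc(=O)cc(C)c12` differs from compound 3 by 3-fluorophenyl in place of pentyl on a saturated chain carbon bound to a sulfonyl sulfur. For the measured compounds named here, the measured steps that bear on it are those along the sulfonyl chain, from compound 2 to compound 3 and from compound 1 to compound 2; no measured step exchanges a chain for an aromatic ring, so the direction rests on the chain steps alone. An estimate for compound 4 in this assay is 30000 nM, with a range from 5000 nM to 150000 nM, which is expected to correspond to an at least 3.3-fold lower number from compound 3 to compound 4 (0.52 log units; beyond the scatter).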

Compound 4, half-maximal inhibitory concentration: 21300 nM
Estimate against measurement, compound 4: 1.4-fold (0.15 log units) above; the measured number falls inside the stated range.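

Against hexyl, 3-fluorobenzyl on the sulfonyl sulfur returns the series to a measured value in this assay, with an at least 4.6-fold lower number from compound 3 to compound 4 (0.67 log units; beyond the scatter). The position therefore accepts a substituent carrying an aromatic ring, which the chain-only compounds could not show, although the propylsulfonyl of compound 2 stays ahead, with a 3.0-fold higher number from compound 2 to compound 4 (0.48 log units; beyond the scatter). The first of these steps has only a bound on its size, as the value of compound 3 is a limit: the limit of > 100000 nM in this assay, at which 2 of the 4 values shown sit.

Going by these compounds, whether the gain over hexyl belongs to the aromatic ring or to its fluorine stays open, and a plain benzyl group would separate the two. Also open, on these data alone, is how a butyl chain would read, and so how narrow the chain length around propyl really is.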